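The compounds below may be only part of what the source reports. "The series", "measured", "known", "first", "only" and "open" are said of these compounds alone.

Measured in a functional assay on T47D cells (Homo sapiens) for inhibition, read by CCK-8 assay, with a stated time of 72 h, tested at 1 uM (on this read-out lower numbers stand for less inhibition of growth and higher numbers for more inhibition of growth at the one concentration tested), so far

- compound 1 `Cc1cccc(NC(=O)C2(C(=O)Nc3ccc(Nc4ncc5cc(C(=O)N(C)C)n(C6CCCC6)c5n4)cc3)CC2)c1` gives 45.7%
- compound 2 `CN(C)C(=O)c1cc2cnc(Nc3ccc(NC(=O)C4(C(=O)Nc5ccccc5F)CC4)cc3)nc2n1C1CCCC1` gives 85.2%
- compound 3 `Cc1ccc(NC(=O)C2(C(=O)Nc3ccc(Nc4ncc5cc(C(=O)N(C)C)n(C6CCCC6)c5n4)cc3)CC2)cc1` gives 47.9%

Compound 3 sits in the lower pair of the three. The step of a number 2.2 percentage points higher from compound 1 to compound 3 (within the scatter) is the only small one in the set, while the step of a number 37.3 percentage points lower from compound 2 to compound 3 (beyond the scatter) separates the 4-methylphenyl compound from the 2-fluorophenyl compound.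

The next compound is compound 4 `CN(C)C(=O)c1cc2cnc(Nc3ccc(NC(=O)C4(C(=O)Nc5cccc(Br)c5)CC4)cc3)nc2n1C1CCCC1` with 3-bromophenyl in place of 4-methylphenyl on an amide-type nitrogen and the rest of the structure unchanged. Within the data shown here, no measured compound carries bromine, so any reading is indirect. Compound 1 with 3-methylphenyl gives 45.7% and is the closest comparison for 3-bromophenyl. The small step of a number 2.2 percentage points higher from compound 1 to compound 3 (within the scatter) suggests that moving between these aryl groups need not shift this assay much. Against that stands the large step of a number 39.5 percentage points higher from compound 1 to compound 2 (beyond the scatter) which shows that a change of aryl group can also shift the read-out strongly, so the upper side of the range is left wide.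

The expected step is a number 7.1 percentage points higher from compound 3 to compound 4 (within the scatter) and this is estimated to lie within the scatter.

For compound 4 the expected value is 55% with an estimated range from 35% to 80% in this read-out.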

Compound 4, percent growth inhibition at one concentration: 29.1%
Compound 4: middle estimate off by 25.9 percentage points, on the high side; the measured number lies below the stated range.
By their numbers in this assay, from the lowest: compound 4; then compounds 1 and 3 (each within the scatter of the next); then compound 2.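

In this assay this position can now lower the read-out as well as raise it: a number 16.6 percentage points lower from compound 1 to compound 4 (beyond the scatter) for bromo in place of methyl on an aromatic carbon, and a number 18.8 percentage points lower from compound 3 to compound 4 (beyond the scatter) for 3-bromophenyl in place of 4-methylphenyl. The two methylphenyl compounds, within the scatter of each other, therefore do not mark a floor for this aryl position, and compound 4 stands apart from both even though 3-bromophenyl and 3-methylphenyl differ only in that one substituent. The range across the set has widened to a number 56.1 percentage points lower from compound 2 to compound 4 (beyond the scatter) for 3-bromophenyl in place of 2-fluorophenyl, and no measurement available here bears on why these aryl changes read as they do.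

Still open, as far as these compounds go, is whether the high value of compound 2 follows the fluorine or its place on the ring, a question that 3-fluorophenyl and 2-bromophenyl groups would help to separate. Also open, from the compounds shown here alone, is how an unsubstituted phenyl, or a phenyl carrying a methoxy group or a carboxylic acid, would read at this position, and whether the order of the four compounds would hold at other concentrations.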